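The compounds below may be only part of what the source reports. "The series", "measured", "known", "first", "only" and "open" are said of these compounds alone.

Measured compounds:
compound 1 `N#CCCc1ccc2nccc(SC3(C(=O)O)CCC3)c2c1`, 2760 nM
compound 2 `N#CCOc1ccc2nccc(SC3(C(=O)O)CCC3)c2c1`, 680 nM

In an assay on HEK293 cells for inhibition of solute carrier family 22 member 12 (Homo sapiens), read by scintillation counting, with a stated time of 12 min (on this read-out higher numbers stand for weaker inhibition and lower numbers for stronger inhibition), compound 2 gives the lower of the two numbers; compound 1 gives 2760 nM, and the step of a 4.1-fold lower number from compound 1 to compound 2 (0.61 log units; beyond the scatter) separates them, with the move being cyanomethoxy in place of 2-cyanoethyl on an aromatic carbon. Compound 3 `COCCOc1ccc2nccc(SC3(C(=O)O)CCC3)c2c1` shares the core of compound 2 and differs by methoxymethyl in place of cyano on a saturated chain carbon bound to an oxygen on an aromatic ring. Among the compounds with values here, the only measured step, a 4.1-fold lower number from compound 1 to compound 2 (0.61 log units; beyond the scatter), changed the linker between the aromatic carbon and the nitrile rather than the nitrile itself, so it does not speak directly to this change; no measured pair exchanges the cyano group. The expectation for compound 3 in this assay is therefore a small step at most, a 1.5-fold higher number from compound 2 to compound 3 (0.17 log units; within the scatter), and not beyond the scatter. Compound 3 is estimated at 1000 nM, within 400 nM to 3000 nM.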

Compound 3, half-maximal inhibitory concentration: 207 nM
Beside the measured number, compound 3's estimate is 4.8-fold (0.68 log units) above it, and the stated range ends above it.
By their numbers in this assay, from the lowest: compound 3; then compound 2; then compound 1.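

In this assay, the nitrile proves dispensable at this position: methoxymethyl in place of cyano on a saturated chain carbon bound to an oxygen on an aromatic ring gives a 3.3-fold lower number from compound 2 to compound 3 (0.52 log units; beyond the scatter). Measured against the earlier 2-cyanoethyl compound, the 2-methoxyethoxy group gives a 13-fold lower number from compound 1 to compound 3 (1.12 log units; beyond the scatter), a large step where the earlier one was only modest. No accompanying measurement bears on the reason for this gain.

Still open, on these data alone, is whether a plain propoxy group would serve as well as 2-methoxyethoxy, which would show whether the chain's ether oxygen matters at all. It is equally unsettled how a longer chain such as 2-(2-methoxyethoxy)ethoxy, an amine such as 2-aminoethoxy or a carboxylic acid such as carboxymethoxy would compare at the same place on the shared core.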